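Dropping the Methoxy from Compound 2

The source may report more compounds than this note shows. Statements on the series, on what has been measured and on what is new or still open speak of the compounds shown alone.

Compound 2 `COc1cc(/C=N/NC(=O)c2ccncc2)cc(O)c1O` gives 18400 nM in a physicochemical assay, read by spectrophotometry; a higher number here means a weaker inhibitor, a lower number a stronger inhibitor; it stands second highest of three numbers, yet within the scatter of both compound 1 `COc1cc(/C=N/NC(=O)c2ccncc2)cc(OC)c1O` at 17000 nM and compound 3 `COc1cc(/C=N/NC(=O)OCc2ccccc2)cc(O)c1O` at 21300 nM. Compound 4 `O=C(N/N=C/c1ccc(O)c(O)c1)c1ccncc1` differs from compound 2 in one place: hydrogen in place of methoxy on an aromatic carbon. Among the measured compounds shown here, the only measured step that touches this spot is a 1.1-fold higher number from compound 1 to compound 2 (0.03 log units; within the scatter), which swaps the methyl on that oxygen for hydrogen rather than removing the whole group. For the measured compounds named here, no measured step removes a methoxy entirely, so the expectation rests on that small change alone. The step is expected to be a 1.1-fold higher number from compound 2 to compound 4 (0.06 log units; within the scatter), no larger than the scatter. Compound 4 is therefore expected to give 21000 nM, within a range of 9000 nM to 48000 nM.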

Compound 4, half-maximal inhibitory concentration: 6100 nM
For compound 4 the middle estimate is 3.4-fold (0.54 log units) above the measured one, and the stated range ends above it.
By their numbers in this assay, from the lowest: compound 4; then compounds 1, 2 and 3 (each within the scatter of the next).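

Taking the methoxy off entirely does what capping its oxygen did not: in this assay there is a 3.0-fold lower number from compound 2 to compound 4 (0.48 log units; beyond the scatter), beyond the scatter, whereas there is a 1.1-fold higher number from compound 1 to compound 2 (0.03 log units; within the scatter), within it. This aromatic carbon is therefore not indifferent to its group, and hydrogen here gives a stronger inhibitor than methoxy. Nothing available explains why the number falls. 

On these data alone, whether a small group such as fluorine or an amine would keep this gain remains open. So does whether removing the methoxy from compound 3 would have the same effect.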